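The source may hold more compounds than are shown below. What is called first, only, known or untested is meant among the compounds shown, and "the series" means these compounds.

Measured compounds:
Compound 1, `Cc1ccc(Nc2nc(C)c(C(=O)/C=C/c3ccc(Cl)cc3)s2)cc1`: in a functional assay on Bel-7402 cells (Homo sapiens) for cytotoxicity, read by MTT assay (a higher number here means a weaker inhibitor, a lower number a stronger inhibitor), compound 1 gives > 25000 nM, which is a limit of the assay rather than a number.
Compound 2, `Cc1ccc(Nc2nc(C)c(C(=O)/C=C/c3ccccc3)s2)cc1`: in this assay compound 2 gives > 25000 nM, again a limit.
Compound 3, `Cc1ccc(Nc2nc(C)c(C(=O)/C=C/c3ccccc3Cl)s2)cc1`: in this assay compound 3 gives > 25000 nM, also a limit.

Compound 2 therefore stands at the limit, as do the two further values shown: the limit of > 25000 nM in this assay, at which 3 of the 3 values shown sit. Compound 4, `Cc1nc(Nc2ccc(Cl)cc2)sc1C(=O)/C=C/c1ccccc1`, differs from compound 2 by chloro in place of methyl on an aromatic carbon. The steps a step that the two limits leave unreadable from compound 1 to compound 2 and a step that the two limits leave unreadable from compound 2 to compound 3 also concern a chloro on an aromatic carbon, and a step that the two limits leave unreadable from compound 1 to compound 3 moves a chloro as well, but each is left unreadable by the two limits, so none gives a size or direction to carry over. For compound 4 the expectation is that it stays at the limit, an expected step that the limit leaves unreadable from compound 2 to compound 4. The estimate for compound 4 is 30000 nM, expected to lie between 8000 nM and 100000 nM.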

Compound 4, half-maximal inhibitory concentration: > 25000 nM
Compound 4 was reported as a limit (the forecaster's own chance of this, stated with the estimate: 75%); the middle value lies beyond the limit too.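

Compound 2 and compound 4 are both reported only as limits, so no step between them can be read: the limit of > 25000 nM in this assay, at which 4 of the 4 values shown sit.

The compounds shown leave open how far apart their true values lie in this assay, and whether any change to the shared core gives a measurable value.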